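The compounds below may be only part of what the source reports. "The series", "measured", "known", "first", "only" and "open" are said of these compounds alone.

Working notes on the series. Compound 1 `CN(C)c1ccc(-c2nc3c(=O)n(C)c(=O)n(C)c3[nH]2)cc1` carries the shared core with a dimethylamino group on the pendant six-membered carbon ring. In an assay for binding affinity to adenosine receptor A1 (Bos taurus) (a higher number here means a weaker inhibitor, a lower number a stronger inhibitor), compound 1 gives 1.8 nM. Compound 2 `Cn1c(=O)c2nc(-c3ccc(Cl)cc3N)[nH]c2n(C)c1=O` has a chloro group and an amino group on the pendant ring; in this assay compound 2 gives 0.35 nM. Among the measured compounds shown here, of the two numbers measured so far, compound 1 stands at the higher one, and its gap to compound 2 lies beyond the usual scatter; the two compounds differ in more than one place, so no single step between them can be drawn.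

Compound 3 `Cn1c(=O)c2nc(-c3ccc(Br)cc3)[nH]c2n(C)c1=O` is not yet measured. Its change from compound 1 is bromo in place of dimethylamino on an aromatic carbon. For the measured compounds named here, no measured pair of compounds shows this exact change, so the size of the step rests on judgement only. The bromo group is expected to be tolerated at this place, with a small drift toward a higher number rather than none at all: the step from compound 1 to compound 3 is estimated at a 1.9-fold higher number from compound 1 to compound 3 (0.29 log units; within the scatter). For compound 3 the expected value in this assay is 3.5 nM, within a range of 0.8 nM to 14 nM.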

Compound 3, half-maximal inhibitory concentration: 0.75 nM
Estimate against measurement, compound 3: 4.7-fold (0.67 log units) above; the whole stated range lies above it.
By their numbers in this assay, from the lowest: compound 2; then compound 3; then compound 1.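

Among the compounds shown here, the step of a 2.4-fold lower number from compound 1 to compound 3 (0.38 log units; beyond the scatter) in this assay is the first single-place comparison, and it shows that dimethylamino is not needed at this place, on an aromatic carbon para to a large group. Bromo, a single heavy atom with no hydrogen-bond acceptor, takes the place of a group of three heavy atoms with one acceptor, and the number falls rather than rises, so neither the larger group nor its acceptor is required for a low nanomolar value here. No measurement in hand bears on why this change lowers the number.

A single pair cannot separate what is lost with dimethylamino from what is gained with bromo, and the amino and chloro groups of compound 2 still cannot be resolved into separate steps. From the compounds shown here alone, how chloro alone, a methoxy group or a carboxylic acid at this same place would read in this assay remains open, so the step describes one exchange and not a trend across groups.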